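The source may hold more compounds than are shown below. What is called first, only, known or untested is meant among the compounds shown, and "the series" means these compounds.

Measured in a functional assay on Shh Light II cells (Mus musculus) for inhibition, read by a luciferase reporter; on this read-out higher numbers stand for weaker inhibition and lower numbers for stronger inhibition:
- Compound 1 `O=C(Nc1ccccc1Cl)N1CCN(c2nc(-c3ccc4ccccc4n3)no2)CC1`: 140 nM
- Compound 2 `O=C(NC1CCCCC1)N1CCN(c2nc(-c3ccc4ccccc4n3)no2)CC1`: 53 nM
- Compound 3 `O=C(CC1CCCCCC1)N1CCC(c2nc(-c3ccc4ccccc4n3)no2)CC1`: 840 nM

Compound 3 has the highest number of the three, beyond the scatter from both others. Compound 4 `CC(C)c1ccccc1NC(=O)N1CCC(c2nc(-c3ccc4ccccc4n3)no2)CC1` carries (2-isopropylphenyl)amino in place of cycloheptylmethyl on a carbonyl carbon. Among the measured compounds shown here, no measured step makes this exact change. The nearest is modest: a 2.6-fold lower number from compound 1 to compound 2 (0.42 log units; beyond the scatter). Its compounds have an amide-type nitrogen on the carbonyl, as compound 4 will, and compound 1 at 140 nM and compound 2 at 53 nM both read lower than compound 3, though their core differs. A moderate drop is therefore expected in this assay, an estimated 3.0-fold lower number from compound 3 to compound 4 (0.48 log units; beyond the scatter). Compound 4 is estimated at 280 nM, within a range of 90 nM to 800 nM.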

Compound 4, half-maximal inhibitory concentration: 480 nM
Compound 4: the middle estimate sits 1.7-fold (0.23 log units) below what was measured; the measured number falls inside the stated range.
By their numbers in this assay, from the lowest: compound 2; then compound 1; then compounds 4 and 3 (each within the scatter of the next).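

In this assay, placing (2-isopropylphenyl)amino on the carbonyl carbon instead of cycloheptylmethyl gives a 1.8-fold lower number from compound 3 to compound 4 (0.24 log units; within the scatter). On this core, therefore, the two groups cannot be told apart, even though the entering group brings an aromatic ring and a hydrogen-bond donor that the leaving group lacks. No supporting evidence is available to explain this result.

The compounds shown leave open how a morpholine or a piperidine would read on this carbonyl carbon. They also leave open how a carboxylic acid or an amine on the phenyl ring of compound 4 would read.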